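Swapping the triazole N-aryl group for a cyanobenzyl

The source may report more compounds than this note shows. Statements on the series, on what has been measured and on what is new or still open speak of the compounds shown alone.

Two compounds share the same core and differ only in the group on an aromatic nitrogen. Compound 1 `O[C@H](COCCOC[C@@H](O)Cc1cn(-c2cncnc2)nn1)Cc1ccc(-c2ccccc2)cc1` reaches only the limit of the assay, giving > 100000 nM in a functional assay on HCT-116 cells (Homo sapiens) for inhibition, read by MTT assay, with a stated time of 72 h; on this read-out higher numbers stand for weaker inhibition of growth and lower numbers for stronger inhibition of growth. Among the compounds with values here, compound 2 `O[C@H](COCCOC[C@@H](O)Cc1cn(-c2cccnc2)nn1)Cc1ccc(-c2ccccc2)cc1` gives 46800 nM in this assay and is the only compound with a number rather than a limit. Within the data shown here, the one measured step, an at least 2.1-fold lower number from compound 1 to compound 2 (0.32 log units; beyond the scatter), shows that this position can move the read-out, though the starting point is a limit (the limit of > 100000 nM in this assay, at which 1 of the 2 values shown sits). Compound 3 `N#Cc1ccc(Cn2cc(C[C@H](O)COCCOC[C@@H](O)Cc3ccc(-c4ccccc4)cc3)nn2)cc1` carries 4-cyanobenzyl in place of pyridin-3-yl on an aromatic nitrogen. That step changes the same position but brings in a larger group of a different kind, so the measured step is only a loose guide; a change of comparable size in either direction, or none beyond the scatter, is plausible. Compound 3 is estimated at 30000 nM, within 8000 nM to 120000 nM, which means an expected step of a 1.6-fold lower number from compound 2 to compound 3 (0.19 log units; within the scatter).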

Compound 3, concentration for 50% growth inhibition: 8800 nM
Estimate against measurement, compound 3: 3.4-fold (0.53 log units) above; low and high end bracket the measured number.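

In this assay, the change to 4-cyanobenzyl gives a 5.3-fold lower number from compound 2 to compound 3 (0.73 log units; beyond the scatter), so this position can move the read-out by a clearly measured amount, not only against a limit. The ring of the entering group is of carbon only, which shows that a hetero atom in that ring is not needed for a lower number here. Against compound 1 the same change gives an at least 11-fold lower number from compound 1 to compound 3 (1.05 log units; beyond the scatter), but this step is a bound rather than a size, because compound 1 stands at a limit: the limit of > 100000 nM in this assay, at which 1 of the 3 values shown sits.

The compounds shown leave open whether the step belongs to the nitrile or to the benzyl part, as the two enter together. A plain benzyl group, or a carboxylic acid in place of the nitrile, would be needed to tell these apart.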